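Swapping chloro in a series known only by limits

This account rests on a few compounds, and the source may have more. Where it says the series, first, only, none or still open, it means among the compounds named here.

Of the compounds shown here, two have been read in an ADME assay on BJ cells (Homo sapiens) for cytotoxicity, with a stated time of 72 h (on this read-out lower numbers stand for an effect already at smaller amounts and higher numbers for an effect only at larger amounts of compound), and neither gives a number. Compound 1 `COc1cc2ncnc(-n3nc(-c4ccccc4)nc3N)c2cc1OC` gives > 50000 nM, which is a limit of the assay. Compound 2 `COc1cc2nc(Cl)nc(-n3nc(-c4ccccn4)nc3N)c2cc1OC` gives > 13000 nM, which is also a limit. Compound 2 therefore has no exact position, and the two limits cannot be ranked against each other.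

Compound 3 `CCOC(=O)CNc1nc(-n2nc(-c3ccccn3)nc2N)c2cc(OC)c(OC)cc2n1` follows from compound 2 by one change, ((ethoxycarbonyl)methyl)amino in place of chloro on an aromatic carbon, between two ring nitrogen atoms. Within the data shown here, no measured step covers this change, so the expectation in this assay is a judgement resting on the limit of compound 2, > 13000 nM. No step beyond the scatter is expected, and the estimated step is a step that the limit leaves unreadable from compound 2 to compound 3. For compound 3 the estimated value is 25000 nM, with an expected range of 9000 nM to 60000 nM.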

Compound 3, half-maximal effective concentration: > 27000 nM
Compound 3: no number, only a limit (the forecaster's own chance of this, stated with the estimate: 70%); at least 1.0-fold (0.03 log units) between middle value and limit.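

Compound 3 gives > 27000 nM as a limit. Compound 2 likewise stands only as a limit, so no step can be read between compound 2 and compound 3. On these data alone, what stays open is the concentration at which any of the three compounds shows an effect in this assay at all.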